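From cyclopentylmethyl to isobutyl on the shared core

The source may report more compounds than this note shows. Statements on the series, on what has been measured and on what is new or still open speak of the compounds shown alone.

Compound 1 `CCN1CCc2c(sc(NC(=O)Nc3ccc(Cl)cc3)c2C(N)=O)C1` gives 3120 nM
Compound 2 `NC(=O)c1c(NC(=O)Nc2ccc(Cl)cc2)sc2c1CCN(C1CCOCC1)C2` gives 2830 nM
Compound 3 `NC(=O)c1c(NC(=O)Nc2ccc(Cl)cc2)sc2c1CCN(CC1CCCC1)C2` gives 1830 nM

In a functional assay (strain AB) with Danio rerio as the target, read by microscopy, with a stated time of 1 h (a higher number here means that more compound is needed for the effect, a lower number that less compound is needed), compound 3 at 1830 nM stands within the scatter of both compound 1 and compound 2. The unmeasured compound 4 `CC(C)CN1CCc2c(sc(NC(=O)Nc3ccc(Cl)cc3)c2C(N)=O)C1` carries isopropyl in place of cyclopentyl on a saturated chain carbon bound to an amine nitrogen in a ring and so reads as cyclopentylmethyl to isobutyl. Going by the values given here, two measured steps bear on this place: a 1.7-fold lower number from compound 1 to compound 3 (0.23 log units; within the scatter) and a 1.5-fold lower number from compound 2 to compound 3 (0.19 log units; within the scatter) both stayed within the scatter. No step beyond the scatter is therefore expected in this assay and the estimate means a 1.3-fold higher number from compound 3 to compound 4 (0.12 log units; within the scatter) as a small expected drift. Compound 4 is estimated at 2400 nM (expected range 1200 nM to 4800 nM).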

Compound 4, half-maximal effective concentration: 4510 nM
Estimate against measurement, compound 4: 1.9-fold (0.27 log units) below; measured number inside the range.
By their numbers in this assay, from the lowest: compounds 3, 2, 1 and 4 (each within the scatter of the next, the first and the last beyond it).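

In this assay the change from cyclopentyl to isopropyl on a saturated chain carbon bound to an amine nitrogen in a ring gives the only step beyond the scatter among these compounds, with a 2.5-fold higher number from compound 3 to compound 4 (0.39 log units; beyond the scatter) as its size. The substituent on the amine nitrogen therefore can shift this number, yet the two other steps, a 1.6-fold higher number from compound 2 to compound 4 (0.20 log units; within the scatter) and a 1.4-fold higher number from compound 1 to compound 4 (0.16 log units; within the scatter), stay within the scatter. No evidence available here accounts for the step.

Going by these compounds, whether a cyclohexylmethyl group, a benzyl group or a longer chain would stand nearer compound 3 or compound 4 remains open.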